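This account rests on a few compounds, and the source may have more. Where it says the series, first, only, none or still open, it means among the compounds named here.

Compound 2 `O=C(CSc1nc2c(c(=O)n1-c1ccccc1)SCC2)Nc1ncc(-c2ccoc2)cn1` gives 1.5 nM in an assay on L cells for inhibition of Protein-serine O-palmitoleoyltransferase porcupine (Mus musculus), read by reporter gene assay, with a stated time of 24 h (a lower number here means that less compound is needed, a higher number that more compound is needed for the effect), and so holds the lowest of the three numbers at hand. Compound 1 `O=C(CSc1nc2c(c(=O)n1-c1ccccc1)SCC2)Nc1ncc(-c2ccco2)cn1` gives 3.5 nM in this assay. Compound 3 `O=C(CSc1nc2c(c(=O)n1-c1ccc(F)cc1)SCC2)Nc1nc2ccc(C(F)(F)F)cc2s1` gives 100 nM in this assay; it differs from compound 2 in more than one place, so its number shows only how far the numbers in this set reach. Compound 4 `O=C(CSc1nc2c(c(=O)n1-c1ccccc1)SCC2)Nc1ncc(-c2ccccc2)cn1` has not yet been measured; it differs from compound 2 by phenyl in place of furan-3-yl on an aromatic carbon. Going by the values given here, the one measured step that touches the same place is a 2.3-fold lower number from compound 1 to compound 2 (0.37 log units; beyond the scatter), a swap of one five-membered aromatic ring for another. Among the compounds with values here, no measured pair shows a five-membered ring replaced by a six-membered ring of carbon only, so the step to compound 4 rests on that single modest step and on the general closeness of compounds 1 and 2. One therefore expects a small change, a 2.0-fold higher number from compound 2 to compound 4 (0.30 log units; within the scatter), with a somewhat higher number judged more likely than a lower one. For compound 4 the estimate in this assay is 3 nM, expected to lie between 1 nM and 10 nM.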

Compound 4, half-maximal effective concentration: 15 nM
Estimate against measurement, compound 4: 5.0-fold (0.70 log units) below; the whole stated range lies below it.
By their numbers in this assay, from the lowest: compound 2; then compound 1; then compound 4; then compound 3.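

In this assay the swap to phenyl gives a 10-fold higher number from compound 2 to compound 4 (1.00 log units; beyond the scatter) and the matching swap from the other furan gives a 4.3-fold higher number from compound 1 to compound 4 (0.63 log units; beyond the scatter) at this position, on an aromatic carbon para to a large group. The position therefore distinguishes a phenyl ring from both furan rings, beyond the scatter in each case, which the step between the two furans alone could not show. The compounds do not separate the larger ring from the loss of the ring oxygen, and no measurement at hand bears on the cause of the change.

Going by these compounds, whether a pyridyl or thienyl ring, or an amine or a methyl group, on this carbon would stay close to the furans or to phenyl remains open. So does whether the phenyl step carries over to another core.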